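The source may hold more compounds than are shown below. What is called first, only, known or untested is meant among the compounds shown, and "the series" means these compounds.

Compound 1, `COc1cccc(/C=C2\CCC/C(=C\c3cccc([N+](=O)[O-])c3)C2=O)c1OC`, gives 5.59 ug/mL in a functional assay on MDA-MB-231 cells (Homo sapiens) for cytotoxicity, read by MTT assay; on this read-out lower numbers stand for stronger inhibition and higher numbers for weaker inhibition.
Compound 2, `COc1cccc(/C=C2\CCC/C(=C\c3ccc([N+](=O)[O-])cc3)C2=O)c1`, gives 51.4 ug/mL in this assay.

Compound 2 stands as the higher of the two numbers, and compound 1 sits below it by a gap that lies beyond the scatter. Compound 3, `COc1cccc(/C=C2\CCC/C(=C\c3ccc([N+](=O)[O-])cc3)C2=O)c1OC`, is not yet measured; it differs from compound 2 by methoxy in place of hydrogen on an aromatic carbon. Going by the values given here, compound 1 also carries this added methoxy, yet it differs from compound 2 in a second place too, so no single-change step is known. A modest step toward a lower number is expected, since compound 1 with that group shows 5.59 ug/mL. Compound 3 is expected to give 15 ug/mL, within 5 ug/mL to 45 ug/mL. This expectation means a step of a 3.4-fold lower number from compound 2 to compound 3 (0.53 log units; beyond the scatter).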

Compound 3, half-maximal inhibitory concentration: 6.73 ug/mL
Beside the measured number, compound 3's estimate is 2.2-fold (0.35 log units) above it; the range from low to high includes it.
By their numbers in this assay, from the lowest: compounds 1 and 3 (each within the scatter of the next); then compound 2.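

Methoxy in place of hydrogen on an aromatic carbon, ortho to a methoxy group, gives a 7.6-fold lower number from compound 2 to compound 3 (0.88 log units; beyond the scatter) as a single change at this place. With that methoxy present, 4-nitrophenyl in place of 3-nitrophenyl gives a 1.2-fold higher number from compound 1 to compound 3 (0.08 log units; within the scatter) in this assay so these two compounds cannot be told apart. Nothing here shows why the methoxy step occurs.

As far as these compounds go, whether an amine, a carboxylic acid or a longer chain such as ethoxy would behave like methoxy at this place remains open. From the compounds shown here alone, it also remains open whether the two nitrophenyl groups would still match without this methoxy.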